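Chain extension on the isoquinoline amide of compound 2

The source may report more compounds than this note shows. Statements on the series, on what has been measured and on what is new or still open speak of the compounds shown alone.

Measured so far:
Compound 1, `CCCCCCCCCCCCNC(=O)[C@@H](NC(=O)c1cccs1)[C@@H](C)O`: 29200 nM
Compound 2, `CCCCCCCCCCCCNC(=O)[C@@H](NC(=O)c1nccc2ccccc12)[C@@H](C)O`: 65800 nM
Compound 3, `C/C=C/C=C/C(=O)N[C@H](C(=O)NCCCCCCCCCCCC)[C@@H](C)O`: 200000 nM

All three were read in a functional assay on SW-620 cells (Homo sapiens) for cytotoxicity, read by MTT assay, with a stated time of 48 h; a lower number here means a stronger inhibitor, a higher number a weaker inhibitor. Compound 2 stands second highest of the three numbers: compound 1 sits nearest, the step being a 2.3-fold higher number from compound 1 to compound 2 (0.35 log units; beyond the scatter), and compound 3 sits furthest, with a 3.0-fold higher number from compound 2 to compound 3 (0.48 log units; beyond the scatter). Between compound 1 and compound 3 the step is a 6.8-fold higher number from compound 1 to compound 3 (0.84 log units; beyond the scatter).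

Compound 4, `CCCCCCCCCCCCCCNC(=O)[C@@H](NC(=O)c1nccc2ccccc12)[C@@H](C)O`, differs from compound 2 only in the chain: ethyl in place of hydrogen on a saturated chain carbon, ten or more bonds along the chain from an amide-type nitrogen. Every measured step instead changes the group on the carbonyl carbon while the chain stays the same, so none of them bears on this change. Within the data shown here, the series gives no measured step for a chain extension of this kind, and the change adds no ring, no donor and no acceptor. For this assay no step beyond the scatter is therefore expected. Compound 4 is estimated at 65800 nM, with a range from 30000 nM to 145000 nM. That estimate means a step of no change at the digits printed from compound 2 to compound 4 (within the scatter), expected to stay within the scatter.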

Compound 4, half-maximal inhibitory concentration: 30400 nM
Compound 4: the middle estimate sits 2.2-fold (0.34 log units) above what was measured, and the stated range covers the measured number.
By their numbers in this assay, from the lowest: compounds 1 and 4 (each within the scatter of the next); then compound 2; then compound 3.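

In this assay the chain responds to this change: ethyl in place of hydrogen on a saturated chain carbon, ten or more bonds along the chain from an amide-type nitrogen, gives a 2.2-fold lower number from compound 2 to compound 4 (0.34 log units; beyond the scatter) and so moves the number beyond the scatter. This is the first measured step in the series that leaves the group on the carbonyl carbon unchanged, so that group is no longer the only place shown to move the number. No evidence on hand accounts for the step.

From the compounds shown here alone, whether a still longer chain continues the direction from compound 2 to compound 4 remains open. So does whether ethyl in place of hydrogen at this place gives a step of similar size with thiophen-2-yl or penta-1,3-dien-1-yl on the carbonyl carbon, and what an amine on the chain would do.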